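Methylsulfonyl on the Amine Nitrogen of Compound 1

The compounds below may be only part of what the source reports. "The series", "measured", "known", "first", "only" and "open" are said of these compounds alone.

Compound 1 `CCCCc1ccc(CN)c(=O)n1Cc1ccc(-c2ccccc2-c2nn[nH]n2)cc1` is the starting point. Going by the values given here, in a functional assay (aorta) for antagonist activity, with Oryctolagus cuniculus as the target (on this read-out lower numbers stand for stronger inhibition and higher numbers for weaker inhibition), compound 1 gives 20 nM, the highest of the three numbers measured so far. Compound 2 `CCCCc1ccc(CN(Cc2ccccc2)C(C)=O)c(=O)n1Cc1ccc(-c2ccccc2-c2nn[nH]n2)cc1` gives 1 nM in this assay, and compound 3 `CCCCc1ccc(CNS(=O)(=O)c2ccc(C)cc2)c(=O)n1Cc1ccc(-c2ccccc2-c2nn[nH]n2)cc1` gives 9 nM. Two steps lead away from compound 1: a 20-fold lower number from compound 1 to compound 2 (1.30 log units; beyond the scatter), and a 2.2-fold lower number from compound 1 to compound 3 (0.35 log units; beyond the scatter). Between the two substituted amines, a 9.0-fold higher number from compound 2 to compound 3 (0.95 log units; beyond the scatter).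

Compound 4 `CCCCc1ccc(CNS(C)(=O)=O)c(=O)n1Cc1ccc(-c2ccccc2-c2nn[nH]n2)cc1` has not yet been measured. It differs from compound 1 by methylsulfonyl in place of hydrogen on an amine nitrogen. Among the compounds with values here, the step that bears most directly on it is the one from compound 1 to compound 3, where a (4-methylphenyl)sulfonyl entered on the same amine nitrogen and the number fell only modestly; compound 4 carries a methyl where compound 3 carries a 4-methylphenyl on that sulfonyl. The large step from compound 1 to compound 2 involved both an acetyl and a benzyl at once, so it is a weaker guide. For compound 4 a small lowering, or none beyond the scatter, is therefore expected: a 1.3-fold lower number from compound 1 to compound 4 (0.12 log units; within the scatter). Compound 4 is estimated in this assay at 15 nM, with a likely range from 6 nM to 40 nM.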

Compound 4, half-maximal inhibitory concentration: 2 nM
For compound 4 the middle estimate is 7.5-fold (0.88 log units) above the measured one, and the stated range ends above it.
By their numbers in this assay, from the lowest: compounds 2 and 4 (each within the scatter of the next); then compound 3; then compound 1.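

Putting a sulfonyl on this amine nitrogen can do far more than compound 3 suggested: there is a 10-fold lower number from compound 1 to compound 4 (1.00 log units; beyond the scatter) with methylsulfonyl in place of hydrogen, a much bigger drop than the (4-methylphenyl)sulfonyl gave. What sits on the sulfonyl sulfur therefore matters in this assay as well, with a 4.5-fold lower number from compound 3 to compound 4 (0.65 log units; beyond the scatter) when methyl replaces 4-methylphenyl, and there is a 2.0-fold higher number from compound 2 to compound 4 (0.30 log units; within the scatter) that lies within the scatter, so methanesulfonamido cannot be told apart from the acetyl(benzyl)amino group on this read-out. No measurement at hand offers an explanation for these steps.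

Only methyl and 4-methylphenyl are shown on the sulfur, so it remains open whether a longer chain such as ethyl or butyl, or a plain phenyl, would keep the number close to that of compound 4. Also open, going by these compounds, is how a simple acetyl on the amine nitrogen, without the benzyl of compound 2, or an added methyl on the sulfonamide nitrogen of compound 4, would behave in this assay on this same position.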